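Para-substituent swap on the N-aryl ring of the hydroxamate series

The compounds below may be only part of what the source reports. "The series", "measured", "known", "first", "only" and "open" are said of these compounds alone.

Measured compounds:
compound 1 `Cc1ccccc1-n1nc(-c2ccccc2)nc1CNc1ccc(C(=O)NO)cc1` 57.1%
compound 2 `O=C(NO)c1ccc(NCc2nc(-c3ccccc3)nn2-c2ccc(Br)cc2)cc1` 65.9%
compound 3 `O=C(NO)c1ccc(NCc2nc(-c3ccccc3)nn2-c2ccc(F)cc2)cc1` 67.6%

In an assay on Sf9 cells for inhibition of protein deacetylase HDAC6 (Homo sapiens), read by fluorescence, with a stated time of 40 min, tested at 100 nM (on this read-out lower numbers stand for less inhibition and higher numbers for more inhibition at the one concentration tested (going by the name of the read-out)), compound 3 gives the highest of the three numbers, but its lead over compound 2 is only a number 1.7 percentage points higher from compound 2 to compound 3 (within the scatter), which is within the scatter, so the two cannot be ordered. The clear gap is to compound 1: a number 10.5 percentage points higher from compound 1 to compound 3 (beyond the scatter), and the related step of a number 8.8 percentage points higher from compound 1 to compound 2 (within the scatter) points the same way but stays within the scatter.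

Compound 4 `O=C(NO)c1ccc(NCc2nc(-c3ccccc3)nn2-c2ccc(C(F)(F)F)cc2)cc1` differs from compound 3 by trifluoromethyl in place of fluoro on an aromatic carbon. Among the compounds with values here, the one measured step that touches the same position, fluoro against bromo in a number 1.7 percentage points higher from compound 2 to compound 3 (within the scatter), is small and within the scatter; no measured compound carries a trifluoromethyl, so the size of this particular group has no precedent here. On that basis the expectation for compound 4 is a step of a number 1.6 percentage points lower from compound 3 to compound 4 (within the scatter), that is, no movement beyond the scatter. Compound 4 is therefore estimated at 66%, with a range from 55% to 77%.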

Compound 4, a percentage reported as inhibition, at one concentration (the size of the read-out at that concentration, not a potency): 38.9%
Estimate against measurement, compound 4: 27.1 percentage points above; the measured number lies below the stated range.
By their numbers in this assay, from the lowest: compound 4; then compounds 1, 2 and 3 (each within the scatter of the next, the first and the last beyond it).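

In this assay, the group at this position is not interchangeable: trifluoromethyl lies well under both fluoro (a number 28.7 percentage points lower from compound 3 to compound 4 (beyond the scatter)) and bromo (a number 27 percentage points lower from compound 2 to compound 4 (beyond the scatter)), although the fluoro and bromo compounds could not be separated. The 2-methylphenyl compound also no longer marks the low end of the series, as 4-(trifluoromethyl)phenyl in its place gives a step downward (a number 18.2 percentage points lower from compound 1 to compound 4 (beyond the scatter)), opposite in direction to the step upward seen with 4-fluorophenyl (a number 10.5 percentage points higher from compound 1 to compound 3 (beyond the scatter)). Nothing at hand explains the loss seen with trifluoromethyl.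

Still open, on these data alone, is whether this loss is particular to trifluoromethyl or also extends to other groups at this position, such as methyl, methoxy, a nitrile or an amine. A single concentration also gives no potency for any of the four compounds.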